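Indole-isoxazoline pyridines: N-benzylation of compound 2

A few compounds are considered here, and "the series" means these few. Any claim that something is new, unique, unknown or untested is made for them only; others in the source may bear on it.

Compound 1 `c1ccc2c(C3CC(c4ccncc4)=NO3)c[nH]c2c1`: > 100000 nM
Compound 2 `COc1ccc2c(C3CC(c4ccncc4)=NO3)c[nH]c2c1`: 10500 nM
Compound 3 `COc1ccc2[nH]cc(C3CC(c4ccncc4)=NO3)c2c1`: > 100000 nM

In a functional assay on PC-3 cells (Homo sapiens) for inhibition, read by MTT assay, with a stated time of 48 h (on this read-out higher numbers stand for weaker inhibition and lower numbers for stronger inhibition), compound 1 gives only a limit, > 100000 nM. Compound 3 likewise gives only a limit in this assay, > 100000 nM. Among the measured compounds shown here, compound 2 holds the one real number in this assay, 10500 nM. The step of an at least 9.5-fold lower number from compound 1 to compound 2 (0.97 log units; beyond the scatter) stands as at least modest; the step that the two limits leave unreadable from compound 1 to compound 3 cannot be sized, since both values sit at the limit of > 100000 nM in this assay, at which 2 of the 3 values shown sit.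

Compound 4 `COc1ccc2c(C3CC(c4ccncc4)=NO3)cn(Cc3ccc(Cl)cc3)c2c1` differs from compound 2 by 4-chlorobenzyl in place of hydrogen on an aromatic nitrogen. For the measured compounds named here, no measured step touches the aromatic nitrogen, so none bears directly on this change. For compound 4 the expected step is therefore small, a 1.8-fold lower number from compound 2 to compound 4 (0.24 log units; within the scatter), with wide uncertainty. Compound 4 is estimated at 6000 nM, between 1000 nM and 40000 nM.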

Compound 4, half-maximal inhibitory concentration: 95100 nM
For compound 4 the middle estimate is 16-fold (1.20 log units) below the measured one; measured number above the stated range.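

On the aromatic nitrogen of compound 2, this assay responds to substitution: 4-chlorobenzyl in place of hydrogen gives a 9.1-fold higher number from compound 2 to compound 4 (0.96 log units; beyond the scatter). Among the compounds shown here, this is the first readable change at this position, and it runs towards weaker inhibition, the opposite direction to the methoxy step an at least 9.5-fold lower number from compound 1 to compound 2 (0.97 log units; beyond the scatter). Compound 4 keeps a real number, yet the series stays crowded at the top of the range: the limit of > 100000 nM in this assay, at which 2 of the 4 values shown sit.

Going by these compounds, whether the loss belongs to the benzyl ring or to its chlorine stays open. On these data alone, how this nitrogen responds to a methyl group or an aminoethyl chain also stays open.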